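Swapping a Halogenated Ring and Watching Cell Toxicity

The source may hold more compounds than are shown below. What is called first, only, known or untested is meant among the compounds shown, and "the series" means these compounds.

Compound 2 `COc1ccc(/C=C2\CCC/C(=C\c3cccc(Br)c3)C2=O)cc1` and compound 1 `COc1ccc(/C=C2\CCC/C(=C\c3c(Cl)cccc3Cl)C2=O)cc1` share a core and differ only by 2,6-dichlorophenyl in place of 3-bromophenyl on a double-bonded chain carbon bound to a double-bonded ring carbon. In an ADME assay on Vero cells (Chlorocebus sabaeus) for inhibition (on this read-out lower numbers stand for higher toxicity in this test and higher numbers for lower toxicity in this test), compound 2 gives 30000 nM, and compound 1 gives 232000 nM, so the step of a 7.7-fold higher number from compound 2 to compound 1 (0.89 log units; beyond the scatter) moved toward lower toxicity. Compound 3 `COc1cccc(/C=C2\CCC/C(=C\c3cccc(Br)c3)C2=O)c1OC` carries a different core; how its core differs from that of compound 2 is not broken down here. In this assay compound 3 gives 31500 nM. Compound 4 `COc1cccc(/C=C2\CCC/C(=C\c3c(Cl)cccc3Cl)C2=O)c1OC` is not yet measured and differs from compound 3 by 2,6-dichlorophenyl in place of 3-bromophenyl on a double-bonded chain carbon bound to a double-bonded ring carbon, the same change as that from compound 2 to compound 1. Because the earlier step of a 7.7-fold higher number from compound 2 to compound 1 (0.89 log units; beyond the scatter) was modest but clear, a comparable step is expected here: the estimated step is a 6.3-fold higher number from compound 3 to compound 4 (0.80 log units; beyond the scatter). Compound 4 is therefore expected to give about 200000 nM, most likely between 80000 nM and 400000 nM.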

Compound 4, half-maximal cytotoxic concentration: 160000 nM
Beside the measured number, compound 4's estimate is 1.3-fold (0.10 log units) above it, and the stated range covers the measured number.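

In this assay, putting 2,6-dichlorophenyl in place of 3-bromophenyl gave a 5.1-fold higher number from compound 3 to compound 4 (0.71 log units; beyond the scatter), the same direction as on the core of compound 2. The two steps also agree in size: the same change on two cores in this assay, a 7.7-fold higher number (0.89 log units; beyond the scatter) from compound 2 to compound 1 and a 5.1-fold higher number (0.71 log units; beyond the scatter) from compound 3 to compound 4, 1.5-fold (0.18 log units) apart, within the scatter of two such steps. This shows that the change carried over between these two cores in this one cell test, but it does not show that it would carry over to any other core.

The swap alters the type and number of halogens together, and the compounds shown cannot tell which of these matters. Also open, going by these compounds, is how this test would read with an amine or a carboxylic acid on that ring instead of halogens.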